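The source may hold more compounds than are shown below. What is called first, only, known or untested is meant among the compounds shown, and "the series" means these compounds.

Measured in a functional assay (brain) for displacement of a labelled ligand, with Rattus norvegicus as the target; a lower number here means a stronger inhibitor, a higher number a weaker inhibitor:

- compound 1 `CC[C@]1(c2ccsc2)OC[C@H]([C@@H]2CCCCN2)O1`: 124 nM
- compound 2 `NC[C@H]1COC(c2ccccc2)(c2ccccc2)O1`: 1400 nM

Compound 2 holds the higher of the two numbers in this assay. Its nearest neighbour is compound 1, whose value stands well lower, a gap that is beyond the usual scatter of repeated measurements; the two compounds differ at several points, so nothing is read from the comparison beyond what the two values show.

Compound 3 `CNC[C@H]1COC(c2ccccc2)(c2ccccc2)O1` has not yet been measured in this assay. Relative to compound 2 the change is methyl in place of hydrogen on an amine nitrogen. For the measured compounds named here, no single-point step between measured compounds is available for this kind of change on this core, so there is no internal calibration for it.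

Expectation: a change of this size is expected to move the number little, and the step of a 1.4-fold lower number from compound 2 to compound 3 (0.15 log units; within the scatter) is estimated to fall within the usual scatter, with no firm direction. On that basis compound 3 is expected to give about 1000 nM in this assay, with a range from 300 nM to 4000 nM.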

Compound 3, inhibition constant: 7300 nM
The estimate for compound 3 lay 7.3-fold (0.86 log units) below the measured number; the whole stated range lies below it.
By their numbers in this assay, from the lowest: compound 1; then compound 2; then compound 3.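

In this assay, methyl in place of hydrogen on an amine nitrogen is not a neutral change on this core: a 5.2-fold higher number from compound 2 to compound 3 (0.72 log units; beyond the scatter), with the aminomethyl compound holding the lower number and the (methylamino)methyl compound the higher. For the compounds shown here, this is the first single-point reading at this amine nitrogen, and it gives the change a direction that compound 1 and compound 2, which differ at several points, could not provide. Going by these compounds alone, the single step is one observation on one core, so it sets no general rule for this nitrogen, and nothing measured here bears on what lies behind the rise.

Going by these compounds, whether the number climbs further with a longer chain such as ethyl on this nitrogen, or with a second methyl on the same nitrogen, remains open, as does how an amide at this position would read in this assay. Also open, on these data alone, is whether methyl in place of hydrogen has a similar effect on the amine of compound 1, whose core differs from that of compound 2 at several points.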